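From a carbamate-bearing amide to a plain anilide

The compounds below may be only part of what the source reports. "The series", "measured", "known", "first", "only" and "open" are said of these compounds alone.

Compound 1, `CCCSc1nc(Cl)c2c(n1)N(Cc1cccs1)C(C(=O)N1CCN(C)CC1)N2`, in a functional assay on MGC-803 cells (Homo sapiens) for antiproliferative activity, read by MTT assay, with a stated time of 72 h (a higher number here means a weaker inhibitor, a lower number a stronger inhibitor), gives 62300 nM.
Compound 2, `CCCSc1nc(Cl)c2c(n1)N(Cc1ccccc1)C(C(=O)NCCNC(=O)OC(C)(C)C)N2`, in this assay gives > 64000 nM.

The value of compound 2 is a limit of the assay and not a number (the limit of > 64000 nM in this assay, at which 1 of the 2 values shown sits). Compound 1 does give a number, a weak one. Compound 3, `CCCSc1nc(Cl)c2c(n1)N(Cc1ccccc1)C(C(=O)Nc1ccccc1)N2`, differs from compound 2 in one place: phenyl in place of 2-((tert-butoxycarbonyl)amino)ethyl on an amide-type nitrogen. Within the data shown here, no measured pair shows this change, so no step can be leaned on. The step expected is an at least 1.4-fold lower number from compound 2 to compound 3 (0.15 log units; that floor lies within the scatter), small and within the usual scatter, if anything toward stronger inhibition. Compound 3 is expected at 45000 nM, between 9000 nM and 64000 nM.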

Compound 3, half-maximal inhibitory concentration: 58400 nM
For compound 3 the middle estimate is 1.3-fold (0.11 log units) below the measured one; the measured number falls inside the stated range.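

Phenyl in place of 2-((tert-butoxycarbonyl)amino)ethyl on an amide-type nitrogen gives a number at this position: in this assay compound 3 gives 58400 nM. The change reads as an at least 1.0-fold lower number from compound 2 to compound 3 (0.03 log units; that floor lies within the scatter), so only a floor on its size is known, and that floor shows no gain beyond the scatter. Compound 2 stands at a limit of the assay and not at a number: the limit of > 64000 nM in this assay, at which 1 of the 3 values shown sits.

From the compounds shown here alone, the true size of this step stays open. So does what a free amine, a carboxylic acid or a longer chain on this amide-type nitrogen would give.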